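This account rests on a few compounds, and the source may have more. Where it says the series, first, only, none or still open, it means among the compounds named here.

Among the measured compounds shown here, in an assay on HEK293 cells for antagonist activity at P2X purinoceptor 7 (Homo sapiens), read by fluorescence, with a stated time of 2 h (on this read-out lower numbers stand for stronger inhibition and higher numbers for weaker inhibition), compound 2 `O=C(c1ccc([N+](=O)[O-])cc1)N1CCC(n2cncc2-c2ccc(OS(=O)(=O)c3cccc4cnccc34)cc2)CC1` gives 1.49 nM, the lowest of the two numbers measured so far; compound 1 `COc1ccc(C(=O)N2CCC(n3cncc3-c3ccc(OS(=O)(=O)c4cccc5cnccc45)cc3)CC2)cc1` gives 77 nM. For the measured compounds named here, the only step measured, a 52-fold lower number from compound 1 to compound 2 (1.71 log units; beyond the scatter), came from nitro in place of methoxy. Compound 3 `CC(C)c1ccc(C(=O)N2CCC(n3cncc3-c3ccc(OS(=O)(=O)c4cccc5cnccc45)cc3)CC2)cc1` differs from compound 2 by isopropyl in place of nitro on an aromatic carbon. Isopropyl is neither of the two groups already tried, so the single step that bears on it, a 52-fold lower number from compound 1 to compound 2 (1.71 log units; beyond the scatter), is only a rough guide; a clearly higher number than compound 2 is expected, though probably not as high as for compound 1. For compound 3 the expected value is 20 nM, within 5 nM to 80 nM, a step of a 13-fold higher number from compound 2 to compound 3 (1.13 log units; beyond the scatter).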

Compound 3, half-maximal inhibitory concentration: 55 nM
Estimate against measurement, compound 3: 2.8-fold (0.44 log units) below, and the stated range covers the measured number.
By their numbers in this assay, from the lowest: compound 2; then compounds 3 and 1 (each within the scatter of the next).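

In this assay, isopropyl in place of nitro at this place on the ring gives a 37-fold higher number from compound 2 to compound 3 (1.57 log units; beyond the scatter), so the low number of compound 2 does not carry over to a group of the same heavy-atom count. Isopropyl and methoxy cannot be told apart, with a 1.4-fold lower number from compound 1 to compound 3 (0.15 log units; within the scatter), which leaves nitro alone among the three groups at the low end; nothing available explains this. As far as these compounds go, whether a nitrile, a trifluoromethyl or a carboxylic acid at this place would come close to nitro stays open.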